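The compounds below may be only part of what the source reports. "The series", "measured", "known", "first", "only" and "open" are said of these compounds alone.

Measured so far:
- Compound 1 `C=CCc1ccc(OC)c(-c2cc(CO)on2)c1`: > 200000 nM (a limit)
- Compound 2 `CCOC(=O)COCc1cc(-c2cc(Br)ccc2OC)no1`: > 200000 nM (a limit)

Both readings come from a functional assay on BV-2 cells (Mus musculus) for inhibition, read by Griess assay, with a stated time of 24 h; a higher number here means a weaker inhibitor, a lower number a stronger inhibitor. Compound 2 stands at > 200000 nM, which is a limit of the assay and not a number. For the measured compounds named here, it has no company at a numerical value: the series so far shows (the limit of > 200000 nM in this assay, at which 2 of the 2 values shown sit). Going by the values given here, no pair of measured compounds differing in one place is available, and no size of step can be read from the data.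

The next compound is compound 3 `C=CCc1ccc(OC)c(-c2cc(COCC(=O)OCC)on2)c1`, which keeps the side chain of compound 2 and changes one substituent: allyl in place of bromo on an aromatic carbon. The allyl group enters on an aromatic carbon, para to a methoxy group, in place of bromo.

Compound 1 also carries the allyl group and is held at the limit > 200000 nM. On that basis, no step beyond the scatter is expected in this assay, and a further limit reading is the likeliest outcome. The expected change is a number no higher from compound 2 to compound 3 (the limit leaves the size open). For compound 3 the estimated value is 200000 nM, with an expected range of 70000 nM to 400000 nM.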

Compound 3, half-maximal inhibitory concentration: 25900 nM
For compound 3 the middle estimate is 7.7-fold (0.89 log units) above the measured one; measured number below the stated range.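

In this assay, the aromatic position para to a methoxy group proves responsive: allyl in place of bromo gives an at least 7.7-fold lower number from compound 2 to compound 3 (0.88 log units; beyond the scatter). The side chain responds too, with (ethoxycarbonyl)methyl in place of hydrogen on the oxygen giving an at least 7.7-fold lower number from compound 1 to compound 3 (0.88 log units; beyond the scatter), so within these three compounds each change shows its step only where the other group is already present: compound 1 has the allyl group without the (ethoxycarbonyl)methyl group, compound 2 has the (ethoxycarbonyl)methyl group without the allyl group, and neither gives a numerical reading. Compound 3 is therefore the only compound here with a number, while the other two remain at a limit of the assay: the limit of > 200000 nM in this assay, at which 2 of the 3 values shown sit.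

On these data alone, the true size of both steps stays open, as each starts from a limit and not from a number. Also open, as far as these compounds go, is whether the gain belongs to the allyl group as such or would survive with a saturated propyl chain at that position, and whether a free carboxylic acid or an amide in place of the ethyl ester would hold the reading of compound 3.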